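From a limit towards a number: compound 3 to compound 4

The source may hold more compounds than are shown below. What is called first, only, known or untested is meant among the compounds shown, and "the series" means these compounds.

For the measured compounds named here, in a functional assay on HeLa cells (Homo sapiens) for cytotoxicity, read by WST assay, with a stated time of 48 h (a lower number here means a stronger inhibitor, a higher number a weaker inhibitor), compound 1 (`COc1cc(C(c2ccc(O)c(OC)c2)[C@@H](C)C(C)C)ccc1O`) gives 19000 nM as the only actual number so far. In this assay compound 2 (`COc1cc(C(c2ccc(O)c(OC)c2)[C@@H](C)[C@H](C)CO)ccc1O`) gives > 100000 nM and this is a limit. In this assay compound 3 (`COC[C@@H](C)[C@@H](C)C(c1ccc(O)c(OC)c1)c1ccc(O)c(OC)c1`) gives > 100000 nM and this too is a limit, so it stands at the limit of > 100000 nM in this assay, at which 2 of the 3 values shown sit, without a number of its own.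

Compound 4 (`CC[C@H](C(C)C)C(c1ccc(O)c(OC)c1)c1ccc(O)c(OC)c1`) has 1-isopropylpropyl in place of 2-(methoxymethyl)-1-methylpropyl on a saturated chain carbon bound to two aromatic carbons. The closest evidence is an at least 5.2-fold higher number from compound 1 to compound 3 (0.72 log units; beyond the scatter) as 2-(methoxymethyl)-1-methylpropyl entered in place of 1,2-dimethylpropyl. A hydroxy on the chain gave a similar result with an at least 5.2-fold higher number from compound 1 to compound 2 (0.72 log units; beyond the scatter) as the measured step. Both steps lie beyond the scatter, while a step that the two limits leave unreadable from compound 2 to compound 3 adds nothing.

The group that leaves compound 3 is thus the one whose entry raised the number from compound 1, so a clear move to a lower number is expected in this assay and not a step within the scatter. The expected size is an at least 6.2-fold lower number from compound 3 to compound 4 (0.79 log units; beyond the scatter) as an estimate resting on a limit. For compound 4 the estimated value is 16000 nM with an expected range of 6000 nM to 45000 nM in this read-out.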

Compound 4, half-maximal inhibitory concentration: 9700 nM
Compound 4: middle estimate off by 1.6-fold (0.22 log units), on the high side; the range from low to high includes it.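

Removing the oxygen from this side chain accounts for the full change in this assay: with 1-isopropylpropyl on the saturated chain carbon bound to two aromatic carbons, the data show an at least 10-fold lower number from compound 3 to compound 4 (1.01 log units; beyond the scatter) and an at least 10-fold lower number from compound 2 to compound 4 (1.01 log units; beyond the scatter). Compound 4 also shows that this position tolerates a change in the all-carbon group, since 1-isopropylpropyl in place of 1,2-dimethylpropyl gives a 2.0-fold lower number from compound 1 to compound 4 (0.29 log units; within the scatter), so these two groups cannot be told apart here. Across the four compounds, the two whose chains carry oxygen have no number of their own, while the two with all-carbon chains do, and none goes against this, but the sizes of the two large steps remain bounded and are not exact: the limit of > 100000 nM in this assay, at which 2 of the 4 values shown sit.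

The compounds shown leave open whether an amine or a fluorine at the same place on the chain would behave like the hydroxy and methoxy groups or like the all-carbon groups. They also leave open whether a longer chain or a cyclohexyl group at this carbon would keep the activity of compound 1 and compound 4 or move it beyond the scatter.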